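The source may report more compounds than this note shows. Statements on the series, on what has been measured and on what is new or still open speak of the compounds shown alone.

Measured so far in a physicochemical assay for solubility, read by HPLC, in phosphate buffer, measured as kinetic solubility, at pH 7.4; a higher number here means a more soluble compound, a lower number a less soluble compound:
- compound 1, `CCOC(=O)c1cc(-c2ccc(Cl)cc2)n(-c2ccc(S(N)(=O)=O)cc2)c1C`: compound 1 gives 4200 nM
- compound 2, `CCC(=O)c1cc(-c2ccc(F)cc2)n(-c2ccc(S(N)(=O)=O)cc2)c1C`: compound 2 gives 29300 nM
- compound 3, `CCOC(=O)c1cc(-c2ccc(Cl)cc2)n(-c2ccc(S(N)(=O)=O)cc2)c1`: compound 3 gives 10800 nM

Compound 2 has the highest of the three numbers; compound 1 has the lowest, and the difference between these two cores is not broken down here. Compound 3 relates to compound 1 by one change, (hydrogen in place of methyl on an aromatic carbon), and that change produced a 2.6-fold higher number from compound 1 to compound 3 (0.41 log units; beyond the scatter).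

Compound 4, `CCC(=O)c1cc(-c2ccc(F)cc2)n(-c2ccc(S(N)(=O)=O)cc2)c1`, is not yet measured. It relates to compound 2 by hydrogen in place of methyl on an aromatic carbon. Going by the values given here, this is the same kind of change as the one from compound 1 to compound 3, though the surroundings differ: in compound 1 the ring atom beside the changed carbon bears an ethoxycarbonyl group and the ring carries a 4-chlorophenyl group, whereas in compound 2 it bears a propanoyl group and the ring carries a 4-fluorophenyl group.

Resting on the step of a 2.6-fold higher number from compound 1 to compound 3 (0.41 log units; beyond the scatter), the step from compound 2 to compound 4 in this assay is expected to be of similar size, a 2.4-fold higher number from compound 2 to compound 4 (0.38 log units; beyond the scatter). Compound 4 is therefore estimated at 70000 nM, most likely between 33000 nM and 150000 nM.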

Compound 4, solubility: 63000 nM
For compound 4 the middle estimate is 1.1-fold (0.05 log units) above the measured one, and the stated range covers the measured number.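

In this assay, hydrogen in place of methyl on an aromatic carbon gave a 2.2-fold higher number from compound 2 to compound 4 (0.33 log units; beyond the scatter), in the same direction as the earlier 2.6-fold higher number from compound 1 to compound 3 (0.41 log units; beyond the scatter), so in these two pairs the change carried from one core to the other with a step of comparable size. Going by these compounds alone, these are only two pairs, and their surroundings differ in two ways at once, a propanoyl group against an ethoxycarbonyl group and a 4-fluorophenyl group against a 4-chlorophenyl group, so the data cannot show whether either difference affects the step or whether it would hold on any other core. Nothing available here accounts for the step.

The compounds shown leave open whether the step would persist with an amine or a carboxylic acid in place of the propanoyl group. They also leave open what a longer chain in place of the methyl on that aromatic carbon would give.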